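A few compounds are considered here, and "the series" means these few. Any claim that something is new, unique, unknown or untested is made for them only; others in the source may bear on it.

Measured so far in a functional assay (spleen, spleen) for activation, with Mus musculus as the target; on this read-out higher numbers stand for an effect only at larger amounts of compound and lower numbers for an effect already at smaller amounts:
compound 1 `CCNc1nc(N)c2nc(O)n(Cc3ccccc3)c2n1` gives 1 uM;
compound 2 `CCCCCNc1nc(N)c2nc(O)n(Cc3ccccc3)c2n1` gives 0.1 uM;
compound 3 `CCSc1nc(N)c2nc(O)n(Cc3ccccc3)c2n1` gives 0.1 uM.

Compound 3 stands level with compound 2 at the digits shown, the two together the lowest of the three numbers; the step of no change at the digits printed from compound 2 to compound 3 (within the scatter) lies within the scatter, whereas a 10-fold lower number from compound 1 to compound 3 (1.00 log units; beyond the scatter) lies beyond it. Compound 4 `CNc1nc(N)c2nc(O)n(Cc3ccccc3)c2n1` has not yet been measured. It differs from compound 3 by methylamino in place of ethylsulfanyl on an aromatic carbon. Going by the values given here, two measured steps bear on this: a 10-fold lower number from compound 1 to compound 3 (1.00 log units; beyond the scatter), here to be read in reverse, and a 10-fold lower number from compound 1 to compound 2 (1.00 log units; beyond the scatter), in which the compound with the shorter chain carries the higher number. Both point the same way, so a higher number than compound 3 is expected, beyond the scatter. Compound 4 is estimated at 2 uM, range 0.5 uM to 10 uM, an expected step of a 20-fold higher number from compound 3 to compound 4 (1.30 log units; beyond the scatter).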

Compound 4, minimum effective concentration: 1 uM
Beside the measured number, compound 4's estimate is 2.0-fold (0.30 log units) above it; low and high end bracket the measured number.
By their numbers in this assay, from the lowest: compounds 2 and 3 (each within the scatter of the next); then compounds 1 and 4 (each within the scatter of the next).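

In this assay, methylamino and ethylamino on this aromatic carbon are not separated, with no change at the digits printed from compound 1 to compound 4 (within the scatter) in the series. Measured against the longer chain, a 10-fold higher number from compound 2 to compound 4 (1.00 log units; beyond the scatter) on removal of the butyl part, and exchange of the sulfur-linked group gives a 10-fold higher number from compound 3 to compound 4 (1.00 log units; beyond the scatter) so both short amino chains stand apart from pentylamino and ethylsulfanyl. Nothing available explains these steps.

Open, from the compounds shown here alone, is whether propylamino or butylamino already reaches the pentylamino value. Also open, going by these compounds, is how methylsulfanyl or pentylsulfanyl would compare with ethylsulfanyl.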